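Halogen swap on the carbonyl-side ring of compound 3

This account rests on a few compounds, and the source may have more. Where it says the series, first, only, none or still open, it means among the compounds named here.

Of the compounds shown here, three have been measured so far. Compound 1 `COc1ccc(-c2cc(/C=C/C(=O)c3ccc(N)cc3)[nH]n2)cc1` gives 100% in a functional assay on SW-620 cells (Homo sapiens) for cytotoxicity, read by sulforhodamine B assay, with a stated time of 48 h, tested at 0.01 uM; a higher number here means a weaker effect of the compound at the concentration tested, a lower number a stronger effect. Compound 2 `COc1cc(-c2cc(/C=C/C(=O)c3ccc(N)cc3)[nH]n2)cc(OC)c1OC` gives 95% in this assay, and compound 3 `COc1cc(-c2cc(/C=C/C(=O)c3ccc(Cl)c(Cl)c3)[nH]n2)cc(OC)c1OC` gives 98% in this assay. Compound 3 thus stands second highest of the three numbers, with compound 1 nearest and compound 2 furthest, yet all three sit within the scatter of one another, so none of them can be called stronger or weaker at this concentration. The new compound 4 `COc1cc(-c2cc(/C=C/C(=O)c3ccc(F)c(F)c3)[nH]n2)cc(OC)c1OC` differs from compound 3 in one place: 3,4-difluorophenyl in place of 3,4-dichlorophenyl on a carbonyl carbon. Among the measured compounds shown here, the only measured step that touches this same place is a number 3 percentage points higher from compound 2 to compound 3 (within the scatter), a change that stayed within the scatter even though it exchanged a whole ring substituent. For the measured compounds named here, with that as the sole guide, no step beyond the scatter is expected here, and the estimated step is a number 1 percentage points lower from compound 3 to compound 4 (within the scatter) in this assay. Compound 4 is accordingly expected to give 97% in this assay, estimated to lie between 88% and 104%.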

Compound 4, a percentage reported as activity, at one concentration (the size of the read-out at that concentration, not a potency): 95%
Beside the measured number, compound 4's estimate is 2 percentage points above it, and the stated range covers the measured number.
By their numbers in this assay, from the lowest: compounds 2, 4, 3 and 1 (each within the scatter of the next).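

In this assay, moving from the two chlorines to the two fluorines on the ring at this carbonyl carbon gives a number 3 percentage points lower from compound 3 to compound 4 (within the scatter) and so leaves the two halogens indistinguishable at this concentration. Exchanging 4-aminophenyl for 3,4-difluorophenyl gives no change at the digits printed from compound 2 to compound 4 (within the scatter) and so adds a third ring substituent pattern at this place without any readable difference, which means that neither swap at this position has yet produced a step beyond the scatter. No supporting measurement is available to explain why these numbers stay so close.

Going by these compounds, whether any group on this carbonyl carbon can move the number beyond the scatter remains open, for example a nitrile or a carboxylic acid on this ring. On these data alone, how these compounds compare at higher concentrations also remains open.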